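Swapping the Aryl Partner for a Triazole Ring

The compounds below may be only part of what the source reports. "The series", "measured", "known", "first", "only" and "open" are said of these compounds alone.

Measured compounds:
Compound 1, `CCC(C)(C)Cc1c[nH]c(CCc2ccc(-c3cccc(C#N)n3)cc2)n1`, gives 26 nM.
Compound 2, `CCC(C)(C)Cc1c[nH]c(CCc2ccc(-c3cccc(C)n3)cc2)n1`, gives 19 nM.

Both numbers come from a functional assay on HEK293 cells for agonist activity at Bombesin receptor subtype-3 (Mus musculus), read by luminescence and calcium flux, with a stated time of 10 min; a higher number here means that more compound is needed for the effect, a lower number that less compound is needed. Among the compounds with values here, compound 2 has the lowest of the two numbers, but its only neighbour is compound 1, and the step of a 1.4-fold lower number from compound 1 to compound 2 (0.14 log units; within the scatter) lies within the scatter, so the two compounds cannot be told apart on these values.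

Compound 3, `CCC(C)(C)Cc1c[nH]c(CCc2ccc(-n3cncn3)cc2)n1`, is the next compound to be measured in this assay. Its change from compound 2 is 1H-1,2,4-triazol-1-yl in place of 6-methylpyridin-2-yl on an aromatic carbon. The ring that enters has fewer heavy atoms and more hetero atoms than the ring that leaves, so this is a larger alteration than the single-group swap seen so far.

Within the data shown here, only one measured step exists, that from compound 1 to compound 2, and it concerns a different position and a much smaller change; it gives no real guide here. Among the measured compounds shown here, with no comparable step, the expectation for compound 3 must be broad. The expected step is a 2.1-fold higher number from compound 2 to compound 3 (0.32 log units; beyond the scatter), a modest loss with wide uncertainty. Compound 3 is therefore estimated at 40 nM, with a range from 10 nM to 200 nM.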

Compound 3, half-maximal effective concentration: 12 nM
Estimate against measurement, compound 3: 3.3-fold (0.52 log units) above; measured number inside the range.
By their numbers in this assay, from the lowest: compounds 3, 2 and 1 (each within the scatter of the next, the first and the last beyond it).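

In this assay, the change from 6-methylpyridin-2-yl to 1H-1,2,4-triazol-1-yl gives a 1.6-fold lower number from compound 2 to compound 3 (0.20 log units; within the scatter), so even this swap of a six-membered aromatic ring with 1 hetero atom for a five-membered aromatic ring with 3 hetero atoms leaves the two compounds indistinguishable, and the group at this place, para to a large group, can differ considerably in ring size and nitrogen count without a readable shift in the number. Within the data shown here, replacing 6-cyanopyridin-2-yl with the same triazole gives a 2.2-fold lower number from compound 1 to compound 3 (0.34 log units; beyond the scatter), the first step to lie beyond the scatter, although it is modest and compound 2 lies within the scatter of both of the others. No accompanying data explain either step.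

The compounds shown leave open whether ring size or the number of ring nitrogens matters more, a question that a plain phenyl ring or a pyrazole at this place could begin to separate. They also leave open whether this place needs an aromatic ring at all, or would accept a non-aromatic group such as an amine, a carboxylic acid or a short alkyl chain.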